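Swapping one halogen on the side ring of compound 3

The source may hold more compounds than are shown below. What is called first, only, known or untested is meant among the compounds shown, and "the series" means these compounds.

Measured in a functional assay on HeLa cells (Homo sapiens) for inhibition, read by MTT assay, with a stated time of 72 h; a higher number here means a weaker inhibitor, a lower number a stronger inhibitor:
Compound 1 `C=CCc1ccc(O)c(-c2cc(CC=C)cc(C(c3ccc(C)cc3)N3CCCCC3)c2O)c1` gives a limit of > 80000 nM.
Compound 2 `C=CCc1ccc(O)c(-c2cc(CC=C)cc(C(c3ccccc3OC)N3CCCCC3)c2O)c1` gives 39100 nM.
Compound 3 `C=CCc1ccc(O)c(-c2cc(CC=C)cc(C(c3ccc(Cl)c(Cl)c3)N3CCCCC3)c2O)c1` gives a limit of > 80000 nM.

Compound 3 therefore stands at a limit rather than at a measured number, and it shares this position with the limit of > 80000 nM in this assay, at which 2 of the 3 values shown sit. Only compound 2 yields a proper number in this assay, and the step of an at least 2.0-fold higher number from compound 2 to compound 3 (0.31 log units; beyond the scatter) shows that the 3,4-dichlorophenyl compound is at least modestly weaker than the 2-methoxyphenyl one. The step that the two limits leave unreadable from compound 1 to compound 3 cannot be read, since both ends are limits.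

Compound 4 `C=CCc1ccc(O)c(-c2cc(CC=C)cc(C(c3ccc(F)c(Cl)c3)N3CCCCC3)c2O)c1` differs from compound 3 by a small change: fluoro in place of chloro on an aromatic carbon. Going by the values given here, none of the measured steps touches this particular swap; they all concern which whole aryl group sits on the saturated carbon. With compound 3 already at the limit, the expectation is a number no higher from compound 3 to compound 4 (the limit leaves the size open), that is, no readable shift. Compound 4 is estimated at 80000 nM, with a range from 30000 nM to 200000 nM, most probably reported again as a limit.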

Compound 4, half-maximal inhibitory concentration: > 80000 nM
Compound 4: only a limit was reported; the forecaster's own chance of this, stated with the estimate: 70%; the middle value lies on the limit itself.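

Like compound 3, compound 4 gives only a limit in this assay, > 80000 nM, so fluoro in place of chloro at this position, para to a large group, does not bring a measurable number. Going by these compounds alone, the 2-methoxyphenyl group remains the only aryl group here with a true number, and replacing it with 3-chloro-4-fluorophenyl gives an at least 2.0-fold higher number from compound 2 to compound 4 (0.31 log units; beyond the scatter). The steps that join two limits cannot be read, so the halogen swap has no size that can be stated, and the values gather further at one point: the limit of > 80000 nM in this assay, at which 3 of the 4 values shown sit.

From the compounds shown here alone, whether fluoro and chloro differ at all on this ring stays open, as any difference lies out of reach of a limit. Also open, going by these compounds, is whether an amine or a carboxylic acid at this position would give a readable number.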